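The compounds below may be only part of what the source reports. "The series", "measured", "known", "first", "only" and "open" are said of these compounds alone.

Measured in a functional assay on MCF7 cells (Homo sapiens) for inhibition, read by sulforhodamine B assay, with a stated time of 48 h; on this read-out higher numbers stand for weaker inhibition of growth and lower numbers for stronger inhibition of growth:

- Compound 1 `CCOC(=O)c1nn(-c2ccc(Cl)cc2)c(-c2ccc(Br)cc2)c1CNC(C)(C)C`: > 511000 nM; > 476000 nM (2 entries), both entries limits of the assay.
- Compound 2 `CCOC(=O)c1nn(-c2ccc(Cl)cc2)c(-c2ccc([N+](=O)[O-])cc2)c1CNC(C)(C)C`: > 548000 nM; 205000 nM (2 entries).
- Compound 3 `CC(C)(C)NCc1c(C(=O)O)nn(-c2ccc(Cl)cc2)c1-c1ccc(Br)cc1`: 221000 nM.

Compound 3 stands apart in this small set. Its 221000 nM is the only single number shown, and the other two compounds have no single number to set beside it.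

Compound 4 `CC(C)(C)NCc1c(C(=O)O)nn(-c2ccc(Cl)cc2)c1-c1ccc([N+](=O)[O-])cc1` has not yet been measured in this assay. It carries nitro in place of bromo on an aromatic carbon, para to a large group, and the change from the 4-bromophenyl to the 4-nitrophenyl compound is nitro in place of bromo on an aromatic carbon.

Among the measured compounds shown here, no step between measured compounds is available to size this change, so the expectation rests on compound 3 at 221000 nM. No step beyond the usual scatter is expected in this assay.

The expected step is a 1.0-fold higher number from compound 3 to compound 4 (0.02 log units; within the scatter).

For compound 4 the estimated value is 230000 nM, with an expected range from 110000 nM to 480000 nM.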

Compound 4, concentration for 50% growth inhibition: 550000 nM
For compound 4 the middle estimate is 2.4-fold (0.38 log units) below the measured one; measured number outside the range, above it.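

In this assay, the change from 4-bromophenyl to 4-nitrophenyl now has a measured size for the carboxylic acids, where nitro in place of bromo gives a 2.5-fold higher number from compound 3 to compound 4 (0.40 log units; beyond the scatter). Among the compounds shown here, that is a modest loss of growth inhibition at this aromatic carbon, and the earlier compounds could not show it, as the same change between the two esters and every step involving them cannot be read. Compound 1 offers only limits of the assay: the several entries of compound 1 in this assay, > 511000 nM; > 476000 nM (2 entries). Compound 2 offers one limit of the assay and one number, far apart from each other: the several entries of compound 2 in this assay, > 548000 nM; 205000 nM (2 entries).

This single step does not show whether the change would have the same size in the ester series. The compounds shown also leave open how an amine or a methoxy group on this aromatic carbon would compare with bromo and nitro.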